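Methoxy to Ethoxy: One Added Methyl

The source may report more compounds than this note shows. Statements on the series, on what has been measured and on what is new or still open speak of the compounds shown alone.

Of the compounds shown here, two sharing one core have been measured so far in an ADME assay on CCRF-CEM cells (Homo sapiens) for antiproliferative activity, with a stated time of 48 h; a lower number here means a stronger inhibitor, a higher number a weaker inhibitor. Compound 1 `C=C(Br)C(=O)Nc1ccc(/C=C/C(=O)c2ccc(I)cc2)cc1`, which carries an iodo group, gives 4000 nM. Compound 2 `C=C(Br)C(=O)Nc1ccc(/C=C/C(=O)c2ccc(OC)cc2)cc1`, with a methoxy group in its place, gives 1400 nM, the lower of the two numbers and so the stronger result.

Compound 3 `C=C(Br)C(=O)Nc1ccc(/C=C/C(=O)c2ccc(OCC)cc2)cc1` differs from compound 2 by methyl in place of hydrogen on a saturated chain carbon bound to an oxygen on an aromatic ring, turning methoxy into ethoxy.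

Among the measured compounds shown here, only one measured step bears on this change. It is a 2.9-fold lower number from compound 1 to compound 2 (0.46 log units; beyond the scatter), a modest move produced by swapping iodo for methoxy on an aromatic carbon. Compound 3 makes a smaller structural edit, since it keeps the oxygen and only extends the chain. One step gives no reliable direction, so no move beyond the scatter is expected. The expected change is a 1.1-fold higher number from compound 2 to compound 3 (0.06 log units; within the scatter). For compound 3 the estimated value is 1600 nM, with an expected range from 700 nM to 3500 nM.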

Compound 3, half-maximal inhibitory concentration: 750 nM
The estimate for compound 3 lay 2.1-fold (0.33 log units) above the measured number; the range from low to high includes it.
By their numbers in this assay, from the lowest: compounds 3 and 2 (each within the scatter of the next); then compound 1.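

Methyl in place of hydrogen on a saturated chain carbon bound to an oxygen on an aromatic ring gives a 1.9-fold lower number from compound 2 to compound 3 (0.27 log units; within the scatter), so in this assay this first test of the chain on the oxygen does not separate ethoxy from methoxy. Ethoxy in place of iodo gives a 5.3-fold lower number from compound 1 to compound 3 (0.73 log units; beyond the scatter), which sits beside the earlier 2.9-fold lower number from compound 1 to compound 2 (0.46 log units; beyond the scatter) and shows that both oxygen-linked groups stand apart from iodo in the same direction, while the added methyl itself makes no difference that can be told from the scatter. Nothing measured here about these groups accounts for these numbers, and no cause can be named for them.

From the compounds shown here alone, a longer chain on the same oxygen, such as propoxy or butoxy, remains open, so a pair of neighbouring chains within the scatter cannot yet show whether chain length matters at all. Also open, going by these compounds, is how a group of another kind, such as an amine or a carboxylic acid, would compare with methoxy and ethoxy on the shared core.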